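Swapping furan for methoxypyrimidine: expected effect on cytotoxicity

This account rests on a few compounds, and the source may have more. Where it says the series, first, only, none or still open, it means among the compounds named here.

Measured compounds:
compound 1 `Cc1cc(-c2ccco2)cc(C)c1Nc1ccnc(Nc2ccc(C#N)cc2)n1`: 1700 nM
compound 2 `Cc1cc(-c2ccc3cc[nH]c3c2)cc(C)c1Nc1ccnc(Nc2ccc(C#N)cc2)n1`: 5800 nM
compound 3 `Cc1cc(-c2cc(F)nc(F)c2)cc(C)c1Nc1ccnc(Nc2ccc(C#N)cc2)n1`: 6300 nM

The three measured compounds share one core and differ only in the aromatic group attached to it. In a toxicity assay on MT4 cells (Homo sapiens) for cytotoxicity, read by MTT assay, with a stated time of 5 days (on this read-out lower numbers stand for higher toxicity in this test and higher numbers for lower toxicity in this test), compound 1 gives the lowest number of the three, so it is the most toxic compound in this set. Exchanging its furan for a larger two-ring group gives a 3.4-fold higher number from compound 1 to compound 2 (0.53 log units; beyond the scatter), and exchanging it for a six-membered ring with two fluorines gives a 3.7-fold higher number from compound 1 to compound 3 (0.57 log units; beyond the scatter). Between those two replacements the difference is a 1.1-fold higher number from compound 2 to compound 3 (0.04 log units; within the scatter), so both changes moved the number by a similar, modest amount.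

Compound 4 `COc1ncc(-c2cc(C)c(Nc3ccnc(Nc4ccc(C#N)cc4)n3)c(C)c2)cn1` carries the change (2-methoxypyrimidin-5-yl in place of furan-2-yl on an aromatic carbon). Within the data shown here, the entering group, like the one in compound 3, is a six-membered ring with two ring nitrogens, and the two measured steps away from the furan both raised the number modestly. A step of similar size and direction is therefore expected here, namely a 2.9-fold higher number from compound 1 to compound 4 (0.47 log units; beyond the scatter). Compound 4 is estimated to give 5000 nM in this assay, with a range from 2500 nM to 10000 nM.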

Compound 4, half-maximal cytotoxic concentration: 4800 nM
Beside the measured number, compound 4's estimate is 1.0-fold (0.02 log units) above it; the measured number falls inside the stated range.
By their numbers in this assay, from the lowest: compound 1; then compounds 4, 2 and 3 (each within the scatter of the next).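

In this assay, 2-methoxypyrimidin-5-yl is a third group that, in place of furan-2-yl at this position, gives a number clearly apart from that of compound 1, with a 2.8-fold higher number from compound 1 to compound 4 (0.45 log units; beyond the scatter), so compound 1 remains the most toxic of the four. The new group also cannot be told apart from the two earlier replacements, with a 1.3-fold lower number from compound 3 to compound 4 (0.12 log units; within the scatter) and a 1.2-fold lower number from compound 2 to compound 4 (0.08 log units; within the scatter), so a two-ring group, a ring bearing two fluorines and a ring bearing a methoxy group all sit at one level in this test, despite their different shapes and atoms. The set now reads as one furan compound standing apart from three similar compounds, though nothing available here explains why the furan compound differs.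

From the compounds shown here alone, whether this lower number is particular to furan-2-yl or would also appear with another five-membered ring, such as thiophen-2-yl, stays open. Also open, going by these compounds, is whether the shared level would hold for a simple phenyl ring or for a ring carrying an amine or a carboxylic acid.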